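Swapping tert-butyl for neopentyl: an expected half-life

The compounds below may be only part of what the source reports. "The series", "measured", "known", "first", "only" and "open" are said of these compounds alone.

Compound 3 `CC(C)N1C(=O)C(=O)N=C1/N=C(/Nc1ccc(Cl)c(Cl)c1)NC(C)(C)C` is the starting point. In an in vitro ADME assay on microsomes from liver (Homo sapiens) for metabolic stability, read by LC-MS (a higher number here means that the compound lasts longer, a lower number that the compound disappears faster), compound 3 gives > 1 h, which is a limit of the assay rather than a number. Two related compounds share the same core. Compound 1 `CON/C(=N\C1=NC(=O)C(=O)N1C(C)C)Nc1ccc(Cl)c(Cl)c1` gives > 1 h in this assay, again a limit. Compound 2 `C=CCON/C(=N\C1=NC(=O)C(=O)N1C(C)C)Nc1ccc(Cl)c(Cl)c1` gives > 1 h, also a limit. Because all three sit at the limit of > 1 h in this assay, at which 3 of the 3 values shown sit, the steps a step that the two limits leave unreadable from compound 1 to compound 3 and a step that the two limits leave unreadable from compound 2 to compound 3 cannot be sized, and a step that the two limits leave unreadable from compound 1 to compound 2 is equally unreadable. Compound 4 `CC(C)N1C(=O)C(=O)N=C1/N=C(\NCC(C)(C)C)Nc1ccc(Cl)c(Cl)c1` differs from compound 3 by neopentyl in place of tert-butyl on an amine nitrogen. With every measured step unreadable, no direction can be set for this change, so a step that the limit leaves unreadable from compound 3 to compound 4 is expected. Compound 4 is therefore estimated at 1.5 h, between 0.7 h and 4 h.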

Compound 4, half-life: > 1 h
Compound 4: no number, only a limit; the forecaster's own chance of this, stated with the estimate: 65%; the middle value is on the limit's open side.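

Compound 4 gives > 1 h in this assay, which is a limit and not a number. No step to compound 4 from compound 1, compound 2 or compound 3 can be read: the limit of > 1 h in this assay, at which 4 of the 4 values shown sit.

Going by these compounds, how long these four compounds actually last, and whether neopentyl and tert-butyl differ at all, stays open.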